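Side-chain swap on compound 3: estimate for compound 4

The compounds below may be only part of what the source reports. "The series", "measured", "known", "first", "only" and "open" are said of these compounds alone.

Three compounds have numbers in a functional assay on MGC-803 cells (Homo sapiens) for cytotoxicity, read by MTT assay, with a stated time of 48 h; a lower number here means a stronger inhibitor, a higher number a weaker inhibitor. Compound 1 `CC1=NN(C(=O)COc2ccc(Cl)cc2)C(c2cc(Br)cc(Br)c2O)C1` gives 50000 nM, compound 2 `COc1ccccc1C1CC(C)=NN1C(=O)CN1CCC(OC)CC1` gives 9550 nM, and compound 3 `Cc1ccc(C(=O)N2N=C(c3cc4ccccc4oc3=O)CC2c2ccccc2)cc1` gives 31300 nM. Compound 3 stands second highest of the three: its number and that of compound 1 sit within the scatter of each other, while compound 2 sits beyond the scatter on the lower side. No pair of these compounds differs in only one place, so no measured step is available to anchor a prediction.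

Compound 4 `O=C(CNC1CCCCC1)N1N=C(c2cc3ccccc3oc2=O)CC1c1ccccc1` is not yet measured. It differs from compound 3 as follows: (cyclohexylamino)methyl in place of 4-methylphenyl on a carbonyl carbon. The entering group brings one hydrogen-bond donor and one hydrogen-bond acceptor where the leaving group had none.

Going by the values given here, with no single-point step, the expected size of the step from compound 3 to compound 4 is uncertain; a modest move toward a lower number is expected, a 2.1-fold lower number from compound 3 to compound 4 (0.32 log units; beyond the scatter), close to the edge of the scatter rather than clearly beyond it. Compound 4 is therefore estimated at 15000 nM, with a plausible range from 4000 nM to 60000 nM.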

Compound 4, half-maximal inhibitory concentration: 26400 nM
For compound 4 the middle estimate is 1.8-fold (0.25 log units) below the measured one, and the stated range covers the measured number.
By their numbers in this assay, from the lowest: compound 2; then compounds 4, 3 and 1 (each within the scatter of the next).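

In this assay, going by these compounds alone, the only single-place step is a 1.2-fold lower number from compound 3 to compound 4 (0.07 log units; within the scatter) and it lies within the scatter, so (cyclohexylamino)methyl and 4-methylphenyl on this carbonyl carbon are not told apart on the shared core. A six-membered non-aromatic ring in place of an aromatic one, together with the added hydrogen-bond donor and acceptor, therefore goes with no readable shift in the number for this pair. No measurement at hand bears on why the number holds across this change.

Going by these compounds, whether a morpholin-4-ylmethyl group, an unsubstituted aminomethyl group or a carboxylic acid on this carbonyl carbon would move the number remains open. Compound 2 differs from compound 3 and compound 4 in more than one place, so what sets its number apart cannot be read from these compounds.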